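Swapping the furan of compound 3 for a bromophenol

The source may report more compounds than this note shows. Statements on the series, on what has been measured and on what is new or still open speak of the compounds shown alone.

Compound 1, `COc1ccc(C(=O)/C=C/c2ccc(F)cc2)c2c1C=CC(C)(C)O2`, in a functional assay on K562 cells (Homo sapiens) for antiproliferative activity, read by MTT assay, with a stated time of 24 h; on this read-out lower numbers stand for stronger inhibition and higher numbers for weaker inhibition: > 10000 nM, a limit of the assay.
Compound 2, `COc1ccc(C(=O)/C=C/c2cccc([N+](=O)[O-])c2)c2c1C=CC(C)(C)O2`, in this assay: 5870 nM.
Compound 3, `COc1ccc(C(=O)/C=C/c2ccco2)c2c1C=CC(C)(C)O2`, in this assay: > 10000 nM, a limit of the assay.

Compound 3 therefore stands at a limit rather than at a number, and it shares that position with one other compound (the limit of > 10000 nM in this assay, at which 2 of the 3 values shown sit). Only compound 2 gives a measured number in this assay.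

Compound 4, `COc1ccc(C(=O)/C=C/c2ccc(O)c(Br)c2)c2c1C=CC(C)(C)O2`, changes the aryl group on the chain: 3-bromo-4-hydroxyphenyl in place of furan-2-yl on a double-bonded chain carbon bound to a double-bonded chain carbon. The measured steps that bear on this are the earlier swaps of the same group at the same place. The step of an at least 1.7-fold higher number from compound 2 to compound 3 (0.23 log units; that floor lies within the scatter) has a floor that lies within the scatter. The step that the two limits leave unreadable from compound 1 to compound 3 cannot be read at all. The step of an at least 1.7-fold lower number from compound 1 to compound 2 (0.23 log units; that floor lies within the scatter) likewise reaches only a floor within the scatter. None of these shows a swap of the aryl group moving the number clearly beyond the scatter, so a large step in this assay is not expected, and a return to a limit remains quite possible.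

For the measured compounds named here, compound 4 is thus expected near the only number measured, at 6000 nM, between 2000 nM and 15000 nM, which would be the estimated step of an at least 1.6-fold lower number from compound 3 to compound 4 (0.22 log units; that floor lies within the scatter).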

Compound 4, half-maximal inhibitory concentration: > 10000 nM
Compound 4: a limit, no number (the forecaster's own chance of this, stated with the estimate: 45%); at least 1.6-fold (0.22 log units) between middle value and limit.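

In this assay compound 4 gives a limit, not a number, so a six-membered aromatic ring carrying bromine and a hydroxy group on this double-bonded chain carbon yields no measured value. For the compounds shown here, the one step that can be read is an at least 1.7-fold higher number from compound 2 to compound 4 (0.23 log units; that floor lies within the scatter), so even this comparison does not clearly separate compound 4 from compound 2, while the steps to compound 4 from compound 1 and from compound 3 join two limits and cannot be read. The 3-bromo-4-hydroxyphenyl group brings a hydrogen-bond donor that the furan-2-yl group lacks, yet this swap still gives no number, and compound 2 remains the only compound with a measured value: the limit of > 10000 nM in this assay, at which 3 of the 4 values shown sit.

As far as these compounds go, the actual numbers of compound 1, compound 3 and compound 4 remain unknown, so these three cannot be ranked against one another. Also open, from the compounds shown here alone, is whether an amine or a carboxylic acid on the aryl ring, or a longer chain in its place, would lower the number clearly beyond the scatter.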